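The source may report more compounds than this note shows. Statements on the series, on what has been measured and on what is new or still open speak of the compounds shown alone.

Three compounds share one core. In a functional assay on MCF7 cells (Homo sapiens) for cytotoxicity, read by MTT assay, with a stated time of 72 h (a lower number here means a stronger inhibitor of growth, a higher number a weaker inhibitor of growth), compound 1 `CCCOC(=O)Nc1ccc([Se]C#N)cc1` gives 34400 nM; compound 2 `CC(C)COC(=O)Nc1ccc([Se]C#N)cc1` gives 45500 nM; compound 3 `C=CCOC(=O)Nc1ccc([Se]C#N)cc1` gives 43100 nM. Compound 3 thus sits between the other two, and all three are within the scatter of one another: a 1.3-fold higher number from compound 1 to compound 3 (0.10 log units; within the scatter) and a 1.1-fold lower number from compound 2 to compound 3 (0.02 log units; within the scatter). Compound 4 `CCOC(=O)Nc1ccc([Se]C#N)cc1` differs from compound 3 by methyl in place of vinyl on a saturated chain carbon bound to an oxygen next to a carbonyl group. The step bearing most directly on a change at this place is a 1.3-fold higher number from compound 1 to compound 3 (0.10 log units; within the scatter), and the remaining step, a 1.3-fold higher number from compound 1 to compound 2 (0.12 log units; within the scatter), also stayed within the scatter. No step beyond the scatter is therefore expected, and a 1.1-fold lower number from compound 3 to compound 4 (0.05 log units; within the scatter) is the estimated step. Compound 4 is expected to give 38000 nM, with a range from 20000 nM to 72000 nM.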

Compound 4, concentration for total growth inhibition: 36700 nM
Compound 4: middle estimate off by 1.0-fold (0.02 log units), on the high side; low and high end bracket the measured number.
By their numbers in this assay, from the lowest: compounds 1, 4, 3 and 2 (each within the scatter of the next).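

Methyl in place of vinyl at this place, on a saturated chain carbon bound to an oxygen next to a carbonyl group, gives a 1.2-fold lower number from compound 3 to compound 4 (0.07 log units; within the scatter) in this assay. Methyl in place of isopropyl gives a 1.2-fold lower number from compound 2 to compound 4 (0.09 log units; within the scatter), and hydrogen in place of methyl, two bonds along the chain, gives a 1.1-fold higher number from compound 1 to compound 4 (0.03 log units; within the scatter), so the ethyl compound extends the flat picture to one more chain, with no step beyond the scatter. No measurement at hand accounts for this flatness.

Going by these compounds, whether an amine, a carboxylic acid or a much longer chain at this place would move the number beyond the scatter stays open.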